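This account rests on a few compounds, and the source may have more. Where it says the series, first, only, none or still open, it means among the compounds named here.

For the measured compounds named here, compound 2 `O=C(O)CCCCCCCOc1ccc2c(=O)c(-c3ccc(O)cc3)coc2c1` gives 6500 nM in an assay (Cricetulus griseus) for inhibition of Monoamine oxidase (Homo sapiens) (a higher number here means a weaker inhibitor, a lower number a stronger inhibitor), the higher of the two numbers so far, though its only neighbour sits within the scatter: compound 1 `O=C(O)CCCCOc1ccc2c(=O)c(-c3ccc(O)cc3)coc2c1` gives 5000 nM, and the step of a 1.3-fold higher number from compound 1 to compound 2 (0.11 log units; within the scatter) tells nothing beyond that scatter. Compound 3 `O=c1c(-c2ccc(O)cc2)coc2cc(OCCCCCCO)ccc12` is the next move: hydroxy in place of carboxymethyl on a saturated chain carbon, six bonds along the chain from an oxygen on an aromatic ring. Going by the values given here, no measured step covers an exchange of carboxy for hydroxy; the single step known, from compound 1 to compound 2, only lengthened the chain while keeping the carboxy, and it changed nothing beyond the scatter. On that thin basis the expected step of a 1.1-fold lower number from compound 2 to compound 3 (0.03 log units; within the scatter) in this assay is no larger than the scatter, in no settled direction. Compound 3 is therefore estimated at 6000 nM, with a range from 2000 nM to 20000 nM.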

Compound 3, half-maximal inhibitory concentration: > 9000 nM
Compound 3 gave a limit, no number; the forecaster's own chance of this, stated with the estimate: 15%; at least 1.5-fold (0.17 log units) between middle value and limit.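

In this assay, for the compounds shown here, compound 3, whose chain ends in hydroxy and not in a carboxylic acid, gives > 9000 nM, which is a limit and not a number; this is the first sign of how the end group, and not the chain length, bears on the read-out. The limit stands alone among the compounds shown: the limit of > 9000 nM in this assay, at which 1 of the 3 values shown sits. The steps are floors, an at least 1.3-fold higher number from compound 2 to compound 3 (0.14 log units; that floor lies within the scatter) and an at least 1.8-fold higher number from compound 1 to compound 3 (0.25 log units; that floor lies within the scatter), so the exchange gave no stronger inhibitor, yet neither floor shows a loss beyond the scatter.

Going by these compounds, how far the true value of compound 3 lies from those of the two acids remains open. Also open, on these data alone, is whether an amine or an amide at the chain end, or a shorter chain carrying hydroxy, would give a lower number.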